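A few compounds are considered here, and "the series" means these few. Any claim that something is new, unique, unknown or untested is made for them only; others in the source may bear on it.

Series notes: amide-linked chromone cores carrying a benzylpiperidine.

Compound 1 `COc1ccc2occ(C(=O)NC3CCN(Cc4ccccc4)CC3)c(=O)c2c1` is measured in an assay on isolated protein for inhibition of Amine oxidase [flavin-containing] B (Homo sapiens), read by fluorescence and Amplex Red, with stated times of 15 min and 20 min; on this read-out lower numbers stand for stronger inhibition and higher numbers for weaker inhibition; in this assay compound 1 gives 46300 nM. Compound 2 `O=C(NC1CCN(Cc2ccccc2)CC1)c1coc2ccc(Br)cc2c1=O` differs from compound 1 by bromo in place of methoxy on an aromatic carbon and in this assay compound 2 gives 22800 nM. That change moves the number a 2.0-fold lower number from compound 1 to compound 2 (0.31 log units; beyond the scatter).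

Compound 3 `COc1ccc2c(=O)c(C(=O)NC3CCN(Cc4ccccc4)CC3)coc2c1` has the same atoms as compound 1 joined differently; the difference between the two cores is not broken down here. In this assay compound 3 gives 28600 nM, which lies within the scatter of compound 2 and of compound 1, so no order among the three is claimed.

Compound 4 `O=C(NC1CCN(Cc2ccccc2)CC1)c1coc2cc(Br)ccc2c1=O` is not yet measured. It differs from compound 3 by bromo in place of methoxy on an aromatic carbon, the same change as from compound 1 to compound 2, with the place described in identical words. For the measured compounds named here, with only one earlier instance of the change, the expectation rests on that single step: a step of similar size is expected, a 2.0-fold lower number from compound 3 to compound 4 (0.31 log units; beyond the scatter), because the earlier step of a 2.0-fold lower number from compound 1 to compound 2 (0.31 log units; beyond the scatter) was modest and beyond the scatter. For compound 4 in this assay a value of 14000 nM is expected, with a plausible range from 7000 nM to 35000 nM.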

Compound 4, half-maximal inhibitory concentration: 19700 nM
Compound 4: the middle estimate sits 1.4-fold (0.15 log units) below what was measured; low and high end bracket the measured number.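

In this assay, bromo in place of methoxy on an aromatic carbon gives a 1.5-fold lower number from compound 3 to compound 4 (0.16 log units; within the scatter), so on this core the change cannot be told apart from repeat scatter, whereas the earlier instance gave a 2.0-fold lower number from compound 1 to compound 2 (0.31 log units; beyond the scatter). The two steps point the same way and do not separate from each other, although only the earlier one clears the scatter: the same change on two cores in this assay, a 2.0-fold lower number (0.31 log units; beyond the scatter) from compound 1 to compound 2 and a 1.5-fold lower number (0.16 log units; within the scatter) from compound 3 to compound 4, 1.4-fold (0.15 log units) apart, within the scatter of two such steps. This fits a small change that carries over between the two cores at a similar size, but it does not show that bromo gains anything on the core of compound 3, and two pairs give no general rule for the series.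

Still open, as far as these compounds go, is whether an amine, a carboxylic acid or a fluoro group in place of methoxy would move the number beyond the scatter on either core. Also open, from the compounds shown here alone, is what a longer chain in place of the benzyl group on the piperidine would do.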